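Inverting one stereocentre in a fast-cleared compound

A few compounds are considered here, and "the series" means these few. Any claim that something is new, unique, unknown or untested is made for them only; others in the source may bear on it.

In an ADME assay on microsomes from liver (Mus musculus) for metabolic stability (on this read-out lower numbers stand for slow clearance and higher numbers for fast clearance), compound 1 `Cc1ccc(S(=O)(=O)Nc2ccc(CN(C)[C@@H]3CCN(C(=O)c4cccc(Cl)c4)C3)cc2)cc1` gives > 50 mL.min-1.g-1, which is a limit of the assay and not a number. Compound 2 `Cc1ccc(S(=O)(=O)Nc2ccc(CN3C[C@@H]4CN(C(=O)c5cccc(Cl)c5)C[C@@H]4C3)cc2)cc1` gives > 50 mL.min-1.g-1, also a limit and not a number. Within the data shown here, compound 3 `COc1ccc(S(=O)(=O)Nc2ccc(CN3CCN(C(=O)C4CN(C(C)=O)C4)CC3)cc2)cc1` gives 1 mL.min-1.g-1, the only true number in the set. Compound 1 therefore stands at the limit of > 50 mL.min-1.g-1 in this assay, at which 2 of the 3 values shown sit.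

Compound 4 `Cc1ccc(S(=O)(=O)Nc2ccc(CN(C)[C@H]3CCN(C(=O)c4cccc(Cl)c4)C3)cc2)cc1` is the counterpart of compound 1: the two compounds have the same atoms and bonds and differ only in configuration as drawn: 1 of 1 stereo elements differ; a stereocentre at a saturated ring carbon is drawn R in compound 1 and S in compound 4. A stereocentre at a saturated ring carbon is drawn R in compound 1 and S in compound 4, and the two compounds have the same atoms and bonds. Among the measured compounds shown here, no measured pair here shows what such an inversion does. The expectation therefore rests on compound 1 with its limit of > 50 mL.min-1.g-1. In this assay the expected a number no higher from compound 1 to compound 4 (the limit leaves the size open) is none beyond the scatter, with no direction favoured. For compound 4 the estimated value is 50 mL.min-1.g-1, with an expected range of 20 mL.min-1.g-1 to 100 mL.min-1.g-1.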

Compound 4, intrinsic clearance in microsomes: > 50 mL.min-1.g-1
Compound 4: no number, only a limit; the forecaster's own chance of this, stated with the estimate: 65%; the middle value lies on the limit itself.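

In this assay compound 4 gives > 50 mL.min-1.g-1 as a limit of the assay and not a number. Compound 1 also sits at a limit, so no step can be read between compound 1 and compound 4. The compounds shown leave open how far either lies past its limit, and whether inverting this stereocentre changes clearance at all.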